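The source may report more compounds than this note shows. Statements on the series, on what has been measured and on what is new or still open speak of the compounds shown alone.

Of the compounds shown here, three have been measured in a functional assay on HCT-116 cells (Homo sapiens) for cytotoxicity, read by scintillation counting and thymidine incorporation, with a stated time of 72 h; on this read-out lower numbers stand for stronger inhibition and higher numbers for weaker inhibition. Compound 1 `CCOc1cc(C(=CC#N)c2ccc(OC)c(F)c2)ccc1OC` gives 130 nM and compound 2 `CC=C(c1cc(OC)cc(OC)c1)c1ccc(OC)c(OC)c1` gives 480 nM. Compound 3 `CC=C(c1cc(OC)cc(OC)c1)c1ccc(OC)c(O)c1` gives 30 nM, the lowest of the three numbers; its nearest neighbour is compound 1 and its furthest is compound 2. Within the data shown here, the only single-place step among them, a 16-fold lower number from compound 2 to compound 3 (1.20 log units; beyond the scatter), concerns hydrogen in place of methyl on an oxygen on an aromatic ring. Compound 4 `COc1cc(OC)cc(C(=Cc2ccccc2)c2ccc(OC)c(O)c2)c1` differs from compound 3 by phenyl in place of methyl on a double-bonded chain carbon bound to a double-bonded chain carbon. Among the measured compounds shown here, no measured step touches the double-bonded chain carbon, and compound 1 differs from compound 3 in several places, so nothing measured bears on this change. One therefore expects no step beyond the scatter, a 1.3-fold higher number from compound 3 to compound 4 (0.12 log units; within the scatter). For compound 4 the estimate is 40 nM, within 10 nM to 160 nM.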

Compound 4, half-maximal inhibitory concentration: > 10000 nM
Compound 4: no number, only a limit (the forecaster's own chance of this, stated with the estimate: 5%); at least 250-fold (2.39 log units) between middle value and limit.
By their numbers in this assay, from the lowest: compound 3; then compound 1; then compound 2. At a limit, above all of these: compound 4.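

Phenyl in place of methyl on a double-bonded chain carbon bound to a double-bonded chain carbon brings an at least 330-fold higher number from compound 3 to compound 4 (2.52 log units; beyond the scatter), the first measured change at this position. The result for compound 4 is a limit of the assay and not a number: the limit of > 10000 nM in this assay, at which 1 of the 4 values shown sits.

So this carbon is not indifferent to what it carries, a point the earlier compounds could not address. The compounds shown leave open whether an aromatic ring is what matters here, or whether an ethyl group, a longer chain or a cyclohexyl ring on this carbon would read the same way.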